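A few compounds are considered here, and "the series" means these few. Any claim that something is new, unique, unknown or untested is made for them only; others in the source may bear on it.

Going by the values given here, compound 1 `COc1cc(-c2cc(/C=C/C(=O)c3ccc(N)cc3)[nH]n2)cc(OC)c1OC` gives the lowest of the two numbers so far: in a functional assay on MDA-MB-468 cells (Homo sapiens) for inhibition, read by sulforhodamine B assay, with a stated time of 48 h (a lower number here means a stronger inhibitor of growth, a higher number a weaker inhibitor of growth), compound 1 gives 1010 nM, while compound 2 `COc1cc(-c2cc(/C=C/C(=O)c3ccc(Cl)c(Cl)c3)[nH]n2)cc(OC)c1OC` gives 1980 nM, a step of a 2.0-fold higher number from compound 1 to compound 2 (0.29 log units; within the scatter). Compound 3 `COc1ccc(-c2cc(/C=C/C(=O)c3ccc(N)cc3)[nH]n2)cc1OC` differs from compound 1 by hydrogen in place of methoxy on an aromatic carbon. The measured step from compound 1 to compound 2 changes the other end of the molecule, so it says nothing about this change. Among the compounds with values here, with no guiding step, no movement beyond the scatter is assumed, and compound 3 is expected to land at 1500 nM, between 500 nM and 5000 nM, a step of a 1.5-fold higher number from compound 1 to compound 3 (0.17 log units; within the scatter).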

Compound 3, concentration for 50% growth inhibition: 1550 nM
Compound 3: middle estimate off by 1.0-fold (0.01 log units), on the low side, and the stated range covers the measured number.
By their numbers in this assay, from the lowest: compounds 1, 3 and 2 (each within the scatter of the next).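

With hydrogen in place of this methoxy, this assay shows a 1.5-fold higher number from compound 1 to compound 3 (0.19 log units; within the scatter). Going by these compounds alone, this is the first look at this position, since the earlier pair differed only at the other end of the molecule, and here the loss of this one methoxy leaves the number within the scatter. No measurement shown gives a reason for this result. Still open, from the compounds shown here alone, is whether another group at this place, such as an amine, a fluorine or an ethoxy, would move the number beyond the scatter. Also open, going by these compounds, is whether the same swap would matter with 3,4-dichlorophenyl on the carbonyl carbon.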